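Chloro exchange in the series: compound 3 to compound 4

A few compounds are considered here, and "the series" means these few. Any claim that something is new, unique, unknown or untested is made for them only; others in the source may bear on it.

Measured values in a functional assay on HL-60 cells (Homo sapiens) for antiproliferative activity, read by MTT assay, with a stated time of 48 h (a higher number here means a weaker inhibitor, a lower number a stronger inhibitor), follow.
compound 1 `COC/C1=C/C[C@](C)(CCC=C(C)C)/C=C/[C@@H](OC(=O)C=C(C)C)[C@](C)(OC)/C=C/C1=O` gives 4050 nM
compound 2 `C=C1/C=C/C(=O)/C(CO)=C\C[C@](C)(CCC=C(C)C)/C=C/[C@H]1OC(=O)C=C(C)C` gives 2810 nM
compound 3 `CC(C)=CCC[C@]1(C)/C=C/[C@@H](OC(=O)C=C(C)C)[C@](C)(O)/C=C/C(=O)/C(CCl)=C\C1` gives 160 nM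

Compound 3 has the lowest number of the three, and both compound 2 and compound 1 lie above it by more than the usual scatter. The next structure is compound 4 `CC(C)=CCC[C@]1(C)/C=C/[C@@H](OC(=O)C=C(C)C)[C@](C)(O)/C=C/C(=O)/C(C[Si](C)(C)C(C)(C)C)=C\C1`, which remains to be measured. Its change from compound 3 is a group of 7 heavy atoms (6 carbon, 1 silicon; no ring) in place of one chlorine atom, on a saturated chain carbon bound to a double-bonded ring carbon, on a saturated chain carbon bound to a double-bonded ring carbon.

Among the measured compounds shown here, no pair of measured compounds differs in one place only, so the size of this step has no direct precedent. For the measured compounds named here, compound 3 at 160 nM is the only chloro compound measured. Neither compound 2 at 2810 nM nor compound 1 at 4050 nM carries chloro, but each also differs from compound 3 elsewhere, so this comparison is weak support. In this assay, a step toward a weaker inhibitor, beyond the scatter, is expected. The expected change is a 9.4-fold higher number from compound 3 to compound 4 (0.97 log units; beyond the scatter). For compound 4 the estimated value is 1500 nM, with an expected range from 300 nM to 8000 nM.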

Compound 4, half-maximal inhibitory concentration: 2770 nM
For compound 4 the middle estimate is 1.8-fold (0.27 log units) below the measured one; low and high end bracket the measured number.
By their numbers in this assay, from the lowest: compound 3; then compounds 4, 2 and 1 (each within the scatter of the next).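

In this assay, the exchange of chloro for the group of 7 heavy atoms (6 carbon, 1 silicon; no ring), on a saturated chain carbon bound to a double-bonded ring carbon, gives a 17-fold higher number from compound 3 to compound 4 (1.24 log units; beyond the scatter) and is a large step. Among the compounds shown here, this pair differs in one place only, so it isolates this position, whereas the earlier compounds each differed from compound 3 elsewhere as well and could not show what a change here alone does to the number. Neither the leaving nor the entering group has a hydrogen-bond donor, a hydrogen-bond acceptor or a net charge, so these counts do not separate the pair, and no measurement at hand bears on the reason for the step.

A single exchange leaves open whether the step reflects the loss of chloro or the arrival of the silicon-bearing group. A bromo group, an amine or a longer all-carbon chain at the same place on the shared core would help separate those two readings, and the answer may differ for each.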